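From Allyl(methyl)amino to a Larger Amide Group

A few compounds are considered here, and "the series" means these few. Any claim that something is new, unique, unknown or untested is made for them only; others in the source may bear on it.

In a functional assay on PC-3 cells (Homo sapiens), read by MTT assay, with a stated time of 48 h (on this read-out lower numbers stand for stronger inhibition and higher numbers for weaker inhibition), compound 1 `CCn1c(C(=O)NCCN)ccc1C(CC)(CC)c1ccc(OCC(O)C(C)(C)C)c(C)c1` gives 940 nM and compound 2 `C=CCN(C)C(=O)c1ccc(C(CC)(CC)c2ccc(OCC(O)C(C)(C)C)c(C)c2)n1CC` gives 25900 nM as the higher of the two numbers. Compound 3 `CCn1c(C(=O)N(CCC#N)CCC#N)ccc1C(CC)(CC)c1ccc(OCC(O)C(C)(C)C)c(C)c1` differs from compound 2 by a group of 9 heavy atoms (6 carbon, 3 nitrogen; no ring) in place of a group of 5 heavy atoms (4 carbon, 1 nitrogen; no ring), on a carbonyl carbon on a carbonyl carbon. For the measured compounds named here, the only measured step, a 28-fold higher number from compound 1 to compound 2 (1.44 log units; beyond the scatter) with allyl(methyl)amino in place of (2-aminoethyl)amino, is large. Compound 3 also lacks (2-aminoethyl)amino, so no step beyond the scatter is expected in this assay here. The estimate means a 1.4-fold lower number from compound 2 to compound 3 (0.16 log units; within the scatter) as the expected step. Compound 3 is expected at 18000 nM with a range from 6000 nM to 50000 nM in this estimate.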

Compound 3, half-maximal inhibitory concentration: 7800 nM
Beside the measured number, compound 3's estimate is 2.3-fold (0.36 log units) above it; measured number inside the range.
By their numbers in this assay, from the lowest: compound 1; then compound 3; then compound 2.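

In this assay, the group of 9 heavy atoms with 2 triple bonds in place of allyl(methyl)amino on this carbonyl carbon gives a 3.3-fold lower number from compound 2 to compound 3 (0.52 log units; beyond the scatter), so the number still shifts among amides lacking (2-aminoethyl)amino. The same group, in place of (2-aminoethyl)amino, gives an 8.3-fold higher number from compound 1 to compound 3 (0.92 log units; beyond the scatter), and so does not recover the lower number of compound 1. No measurement here accounts for either step.

The compounds shown leave open whether a longer chain ending in an amine, such as (3-aminopropyl)amino, would match compound 1. They also leave open what a carboxylic acid at the end of that chain would give.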